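Series notes: amine substituent on the shared core

The compounds below may be only part of what the source reports. "The series", "measured", "known", "first", "only" and "open" are said of these compounds alone.

Measured in a functional assay on HCT-116 cells (Homo sapiens) for cytotoxicity, read by MTT assay, with a stated time of 72 h; a higher number here means a weaker inhibitor, a lower number a stronger inhibitor:
compound 1 `O=C(NCc1ccc(F)cc1)c1nc(Br)c2cccnc2c1NCc1ccccc1` gives > 20000 nM, a limit of this assay.
compound 2 `Nc1ccc(Nc2c(C(=O)NCc3ccc(F)cc3)nc(Br)c3cccnc23)cc1` gives 7000 nM.
compound 3 `COC(=O)CNc1c(C(=O)NCc2ccc(F)cc2)nc(Br)c2cccnc12` gives > 10000 nM, a limit of this assay.

Compound 3 stands at a limit and no number is known for it; the step of an at least 1.4-fold higher number from compound 2 to compound 3 (0.15 log units; that floor lies within the scatter) reads the limit of > 10000 nM in this assay, at which 1 of the 3 values shown sits, against the value of compound 2, while a step that the two limits leave unreadable from compound 1 to compound 3 is unreadable since both compounds sit at limits (the limit of > 20000 nM in this assay, at which 1 of the 3 values shown sits, and (the limit of > 10000 nM in this assay, at which 1 of the 3 values shown sits)).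

Compound 4 `O=C(NCCCNc1c(C(=O)NCc2ccc(F)cc2)nc(Br)c2cccnc12)c1ccccc1` differs from compound 3 in 2-benzamidoethyl in place of methoxycarbonyl on a saturated chain carbon bound to a nitrogen on an aromatic ring. Going by the values given here, the only steps that bear on it are an at least 1.4-fold higher number from compound 2 to compound 3 (0.15 log units; that floor lies within the scatter) and a step that the two limits leave unreadable from compound 1 to compound 3, neither of which gives a readable size, and compound 1 with its own aromatic ring on this nitrogen sits at a limit. Among the compounds with values here, no step is therefore expected beyond the scatter in this assay: a step that the limit leaves unreadable from compound 3 to compound 4. Compound 4 is estimated at 12000 nM, between 3000 nM and 40000 nM.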

Compound 4, half-maximal inhibitory concentration: > 10000 nM
Compound 4 gave a limit, no number; the forecaster's own chance of this, stated with the estimate: 60%; the middle value is on the limit's open side.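

In this assay compound 4 gives > 10000 nM, a limit, and the steps to it from compound 1 and compound 3 cannot be read. From the compounds shown here alone, whether 2-benzamidoethyl and methoxycarbonyl differ at all in this assay stays open.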